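The compounds below may be only part of what the source reports. "The series", "measured", "known", "first", "only" and "open" are said of these compounds alone.

Measured so far:
compound 1 `CC1(C)CC(C)(C)c2cc(NC(=O)Nc3ccc([N+](=O)[O-])cc3)ccc2O1` — 79%
compound 2 `CC1(C)CC(C)(C)c2cc(NC(=S)Nc3ccc(C(F)(F)F)cc3)ccc2O1` — 2%

Compound 1 gives the higher of the two numbers in a functional assay on A2780 cells (Homo sapiens) for inhibition, with a stated time of 72 h, tested at 10 uM; a lower number here means less inhibition of growth, a higher number more inhibition of growth at the concentration tested. Compound 2 shows a number far lower than compound 1, a gap well beyond the usual scatter, but the two structures differ in more than one place, so no single change can be tied to that gap; only what the two values show can be said.

Compound 3 `CC1(C)CC(C)(C)c2cc(NC(=O)Nc3ccc(OC(F)(F)F)cc3)ccc2O1` has not yet been measured in this assay. It differs from compound 1 in one place: trifluoromethoxy in place of nitro on an aromatic carbon. The shared core and the urea linker stay as they are in compound 1.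

Going by the values given here, with no measured pair isolating this change, the expectation rests on the two numbers alone. Compound 1 is the only measured urea, and it sits high; compound 2 sits very low but differs twice, so it gives no clean guide. The step from compound 1 to compound 3 is expected to go downward by a middling amount, a number 34 percentage points lower from compound 1 to compound 3 (beyond the scatter), and is not expected to fall all the way to the level of compound 2. Compound 3 is therefore estimated to reach 45% in this assay, within a wide range from 10% to 78%.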

Compound 3, percent growth inhibition at one concentration: 91.5%
For compound 3 the middle estimate is 46.5 percentage points below the measured one; the measured number lies above the stated range.
By their numbers in this assay, from the lowest: compound 2; then compound 1; then compound 3.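

With the shared core and the urea linker held fixed, placing trifluoromethoxy in place of nitro on the aromatic carbon para to a large group gives a number 12.5 percentage points higher from compound 1 to compound 3 (beyond the scatter) in this assay and counts as a modest step. This single change shows that the nitro group is not required at this position for growth inhibition at the concentration tested, and that a group with more heavy atoms, including three fluorine atoms and no nitrogen, is accepted there. No measurement is available that would explain why the number rises with this swap.

From the compounds shown here alone, it remains open how other groups would behave at this position, for example an amine, a carboxylic acid or a simple methyl, and whether growth inhibition depends on the kind of group placed there or holds up across very different ones. Compound 2 at 2% carries both a thiourea linker and a trifluoromethyl group, so the compounds shown cannot tell which of these two differences goes with its low number.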